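Cyclohexyl analogue with the benzyl-linked hydroxycarbamoyl group

The source may report more compounds than this note shows. Statements on the series, on what has been measured and on what is new or still open speak of the compounds shown alone.

Compound 3 `Cc1ccc(CN2C(=O)N(C3CCCCC3)C(=O)C2CCC(=O)Nc2ccc(C(=O)NO)cc2)cc1` gives 10.3 nM in an assay on isolated protein for inhibition of protein deacetylase HDAC6 (Homo sapiens), read by fluorescence, with stated times of 5 min and 60 min; a higher number here means a weaker inhibitor, a lower number a stronger inhibitor. Among the three compounds measured so far, compound 1 `Cc1ccc(CN2C(=O)N(c3ccc(Cl)cc3)C(=O)C2CCC(=O)Nc2ccc(C(=O)NO)cc2)cc1` gives 4.4 nM in this assay and compound 2 `Cc1ccc(CN2C(=O)N(c3ccc(Cl)cc3)C(=O)C2CCC(=O)NCc2ccc(C(=O)NO)cc2)cc1` gives 18.9 nM. Compound 3 and compound 2 lie within the scatter of each other, whereas the step of a 2.3-fold higher number from compound 1 to compound 3 (0.37 log units; beyond the scatter) lies beyond it, so compound 3 sits clearly above compound 1 on the numbers but is not separable from compound 2.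

Compound 4 `Cc1ccc(CN2C(=O)N(C3CCCCC3)C(=O)C2CCC(=O)NCc2ccc(C(=O)NO)cc2)cc1` differs from compound 3 by 4-(hydroxycarbamoyl)benzyl in place of 4-(hydroxycarbamoyl)phenyl on an amide-type nitrogen. The same change has one precedent in this series, the step of a 4.3-fold higher number from compound 1 to compound 2 (0.63 log units; beyond the scatter), made on the core bearing the 4-chlorophenyl group. The step of a 2.3-fold higher number from compound 1 to compound 3 (0.37 log units; beyond the scatter) does not touch the spacer and bears on the present change only in that it sets the starting point. On that single precedent, a step of like size is expected here, a 4.3-fold higher number from compound 3 to compound 4 (0.63 log units; beyond the scatter), toward a higher number. Compound 4 is accordingly estimated at 44 nM, with a range from 18 nM to 110 nM.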

Compound 4, half-maximal inhibitory concentration: 17 nM
Estimate against measurement, compound 4: 2.6-fold (0.41 log units) above, outside the stated range (below it).
By their numbers in this assay, from the lowest: compound 1; then compounds 3, 4 and 2 (each within the scatter of the next).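

Moving from 4-(hydroxycarbamoyl)phenyl to 4-(hydroxycarbamoyl)benzyl on the cyclohexyl core gives a 1.7-fold higher number from compound 3 to compound 4 (0.22 log units; within the scatter), so this change is not resolved from the scatter on this core, and the two cores cannot be told apart in their response to it: the same change on two cores in this assay, a 4.3-fold higher number (0.63 log units; beyond the scatter) from compound 1 to compound 2 and a 1.7-fold higher number (0.22 log units; within the scatter) from compound 3 to compound 4, 2.6-fold (0.42 log units) apart, within the scatter of two such steps. On the 4-(hydroxycarbamoyl)benzyl side, cyclohexyl in place of 4-chlorophenyl on the amide-type nitrogen in the ring gives a 1.1-fold lower number from compound 2 to compound 4 (0.05 log units; within the scatter), and this too cannot be separated from the step on the 4-(hydroxycarbamoyl)phenyl side: the same change on two cores in this assay, a 2.3-fold higher number (0.37 log units; beyond the scatter) from compound 1 to compound 3 and a 1.1-fold lower number (0.05 log units; within the scatter) from compound 2 to compound 4, 2.6-fold (0.42 log units) apart, within the scatter of two such steps. Any dependence of one place on the other therefore remains unsupported by these four compounds.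

Open, going by these compounds, is how a longer chain carrying the hydroxycarbamoyl-bearing ring would compare with the benzyl. Also open, on these data alone, is how a plain phenyl or a cyclopentyl would compare at the amide-type nitrogen in the ring.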